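The source may hold more compounds than are shown below. What is called first, only, known or untested is meant among the compounds shown, and "the series" means these compounds.

Measured so far:
Compound 1 `O=C1c2ccccc2CN1c1cnc(NCc2c(F)ccc3c2CCO3)n2cnnc12`: 13 mL.min-1.g-1
Compound 2 `CN(C)Cc1ccc2c(c1)CN(c1cnc(NCc3c(F)ccc4c3CCO4)c3cn[nH]c(=O)c13)C2=O`: 32 mL.min-1.g-1
Compound 3 `Cc1nc(CN(C)C)ccc1-c1cnc(NCc2c(F)ccc3c2CCO3)c2cn[nH]c(=O)c12`: 13 mL.min-1.g-1

In an ADME assay on microsomes from liver (Homo sapiens) for metabolic stability, read by LC-MS, using NADPH, with stated times of 5 min and 30 min, tested at 1 uM (a lower number here means slower removal, a higher number faster removal of the compound), compound 1 gives 13 mL.min-1.g-1, level with compound 3 at the digits shown, and together these two sit lowest of the three numbers. Compound 2 gives 32 mL.min-1.g-1, a higher number that lies beyond the usual scatter. The next compound, compound 4 `CC1(C)CC(=O)N(c2cnc(NCc3c(F)ccc4c3CCO4)n3cnnc23)C1`, differs from compound 1 in one place: a group of 8 heavy atoms (6 carbon, 1 nitrogen, 1 oxygen; one five-membered non-aromatic ring with 1 hetero atom) in place of a group of 10 heavy atoms (8 carbon, 1 nitrogen, 1 oxygen; one five-membered non-aromatic ring with 1 hetero atom, one six-membered aromatic ring of carbon only), on an aromatic carbon. No change of this kind has been measured here, so there is nothing to rest a direction on. The step of no change at the digits printed from compound 1 to compound 4 (within the scatter) is expected to stay within the scatter, with no clear direction. For compound 4 the expected value in this assay is 13 mL.min-1.g-1, estimated to lie between 6 mL.min-1.g-1 and 28 mL.min-1.g-1.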

Compound 4, intrinsic clearance in microsomes: 16 mL.min-1.g-1
Estimate against measurement, compound 4: 1.2-fold (0.09 log units) below, and the stated range covers the measured number.
By their numbers in this assay, from the lowest: compounds 1, 3, 4 and 2 (each within the scatter of the next, the first and the last beyond it).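

Swapping the group that holds a six-membered aromatic ring of carbon only for 4,4-dimethyl-2-oxopyrrolidin-1-yl gives a 1.2-fold higher number from compound 1 to compound 4 (0.09 log units; within the scatter) in this assay and so shows that, on this aromatic carbon, that aromatic ring can go while the rate of removal stays level. Nothing shown here explains this outcome. From the compounds shown here alone, it remains open whether a plain 2-oxopyrrolidin-1-yl without the two methyl groups, a morpholine or a carboxylic acid on the same carbon would also stay level with these two compounds.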